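The source may report more compounds than this note shows. Statements on the series, on what has been measured and on what is new or still open speak of the compounds shown alone.

Measured so far:
Compound 1 `Cc1cccc(-c2nc3ccc(C)cc3c(=O)[nH]2)c1`: > 50000 nM (a limit of the assay)
Compound 2 `CCN(CC)c1ccc2nc(-c3ccccc3OC(F)(F)F)[nH]c(=O)c2c1`: 1710 nM

Within the data shown here, in a functional assay on HCT-15 cells (Homo sapiens) for cytotoxicity, read by MTT assay, with a stated time of 2 days (on this read-out higher numbers stand for weaker inhibition and lower numbers for stronger inhibition), compound 2 gives 1710 nM, the only true number so far. Compound 1 reaches only a limit, > 50000 nM.

Compound 3 `CCN(CC)c1ccc2nc(-c3ccccc3C(F)(F)F)[nH]c(=O)c2c1` has trifluoromethyl in place of trifluoromethoxy on an aromatic carbon, ortho to a large group: trifluoromethyl in place of trifluoromethoxy on an aromatic carbon. Among the measured compounds shown here, no measured step shows what this swap does, so with compound 2 at 1710 nM as the sole anchor, no change beyond the scatter is expected in this assay, in either direction. The estimated change is a 1.2-fold higher number from compound 2 to compound 3 (0.07 log units; within the scatter). Compound 3 is expected at 2000 nM, with an estimated range of 700 nM to 6000 nM.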

Compound 3, half-maximal inhibitory concentration: 280 nM
The estimate for compound 3 lay 7.1-fold (0.85 log units) above the measured number; the measured number lies below the stated range.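

Trifluoromethyl in place of trifluoromethoxy, on an aromatic carbon ortho to a large group, gives a 6.1-fold lower number from compound 2 to compound 3 (0.79 log units; beyond the scatter) in this assay, and here a lower number means stronger inhibition. This position therefore responds to a small edit, since the two groups differ by one oxygen atom. The data shown give no reason for this gain.

As far as these compounds go, whether the trend extends beyond this single pair remains open. A chlorine atom, a nitrile or a methoxy group at this place could show how much the group's identity matters.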